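Expecting little change from a 4-nitrophenyl swap

A few compounds are considered here, and "the series" means these few. Any claim that something is new, unique, unknown or untested is made for them only; others in the source may bear on it.

Three compounds sharing one core, and differing in the aromatic group on the chain, have been measured in a functional assay on HeLa cells (Homo sapiens) for cytotoxicity, read by WST assay, with a stated time of 48 h; on this read-out higher numbers stand for weaker inhibition and lower numbers for stronger inhibition. There, compound 1 `O[C@@H](c1ccccc1)[C@H]1CO[C@H](c2ccccc2)[C@@H](C/C=C/c2cccc(F)c2)C1` gives 8380 nM, compound 2 `COc1ccccc1/C=C/C[C@H]1C[C@@H]([C@@H](O)c2ccccc2)CO[C@@H]1c1ccccc1` gives 14700 nM, and compound 3 `Oc1cccc(/C=C/C[C@H]2C[C@@H]([C@@H](O)c3ccccc3)CO[C@@H]2c2ccccc2)c1` gives 18600 nM. Compound 3 therefore stands level with compound 2, as shown by a 1.3-fold higher number from compound 2 to compound 3 (0.10 log units; within the scatter), and only modestly apart from compound 1, as shown by a 2.2-fold higher number from compound 1 to compound 3 (0.35 log units; beyond the scatter).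

Compound 4 `O=[N+]([O-])c1ccc(/C=C/C[C@H]2C[C@@H]([C@@H](O)c3ccccc3)CO[C@@H]2c2ccccc2)cc1` changes one group of compound 3: 4-nitrophenyl in place of 3-hydroxyphenyl on a double-bonded chain carbon bound to a double-bonded chain carbon. In words, 4-nitrophenyl takes the place of 3-hydroxyphenyl on a double-bonded chain carbon. The closest evidence comes from swaps at this same place, such as a 1.8-fold higher number from compound 1 to compound 2 (0.24 log units; within the scatter), and all of these steps are small. Among the measured compounds shown here, no measured compound carries a nitro group, so the data give no clear direction. A step beyond the scatter in this assay is therefore not expected, and the expected step is a 1.3-fold lower number from compound 3 to compound 4 (0.12 log units; within the scatter). The estimated value for compound 4 is 14000 nM, with an expected range from 6000 nM to 32000 nM.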

Compound 4, half-maximal inhibitory concentration: 12400 nM
Beside the measured number, compound 4's estimate is 1.1-fold (0.05 log units) above it; measured number inside the range.
By their numbers in this assay, from the lowest: compounds 1, 4, 2 and 3 (each within the scatter of the next, the first and the last beyond it).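

In this assay the nitro group is new at this place, yet it gives a 1.5-fold lower number from compound 3 to compound 4 (0.18 log units; within the scatter) and also a 1.2-fold lower number from compound 2 to compound 4 (0.07 log units; within the scatter) and a 1.5-fold higher number from compound 1 to compound 4 (0.17 log units; within the scatter) in the same narrow band. The chain carbon therefore accepts 4-nitrophenyl, with its 9 heavy atoms and 0 hydrogen-bond donors, in place of 3-hydroxyphenyl without a step beyond the scatter, and compound 4 cannot be separated from any of the other three compounds, even though compound 1 and compound 3 do lie beyond the scatter of each other. No measurement here accounts for this narrow band.

All four compounds carry a substituted phenyl group on the chain, so a phenyl bearing an amine or a carboxylic acid remains an open case. So does a plain longer alkyl chain with no aromatic ring at this place.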